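Removing the methyl from the 4-methylbenzyl group

A few compounds are considered here, and "the series" means these few. Any claim that something is new, unique, unknown or untested is made for them only; others in the source may bear on it.

In a functional assay on NCI-H460 cells (Homo sapiens) for cytotoxicity, read by MTT assay, with a stated time of 72 h (on this read-out lower numbers stand for stronger inhibition and higher numbers for weaker inhibition), compound 1 `CCN(CC)Cc1ccc2nc(NC(=O)N/N=C/c3cn(Cc4ccc(C)cc4)c4ccccc34)sc2c1` gives 320 nM, and compound 2 `Cc1ccc(Cn2cc(/C=N/NC(=O)Nc3nc4ccc(CN5CCC(C)CC5)cc4s3)c3ccccc32)cc1` gives 410 nM. Compound 1 therefore holds the lower of the two numbers, although the pair lies within the scatter. Compound 3 `CCN(CC)Cc1ccc2nc(NC(=O)N/N=C/c3cn(Cc4ccccc4)c4ccccc34)sc2c1` keeps the core of compound 1 and its diethylamino group, but has hydrogen in place of methyl on an aromatic carbon, para to a large group, turning 4-methylbenzyl into benzyl (hydrogen in place of methyl on an aromatic carbon). Within the data shown here, the one measured step, a 1.3-fold higher number from compound 1 to compound 2 (0.11 log units; within the scatter), places 4-methylpiperidin-1-yl in place of diethylamino. It lies at another site, so it bears on this change only loosely, and no measurement tests the methyl itself. No shift beyond the scatter is therefore expected, and the estimated step is a 1.1-fold higher number from compound 1 to compound 3 (0.04 log units; within the scatter). Compound 3 is expected to give 350 nM, with an estimated range of 170 nM to 750 nM.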

Compound 3, half-maximal inhibitory concentration: 450 nM
The estimate for compound 3 lay 1.3-fold (0.11 log units) below the measured number; low and high end bracket the measured number.
By their numbers in this assay, from the lowest: compounds 1, 2 and 3 (each within the scatter of the next).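

The change of 4-methylbenzyl to benzyl, with the diethylamino group kept, gives in this assay a 1.4-fold higher number from compound 1 to compound 3 (0.15 log units; within the scatter). Among these compounds, this is the first direct test of the methyl, and it shows that this one carbon, on an aromatic carbon para to a large group, can give way to hydrogen without a shift that stands out from repeated measurements. No accompanying measurement speaks to why the number holds at this position.

With only methyl and hydrogen shown here, the compounds leave open whether a chlorine atom, a methoxy group or a carboxylic acid at this place would move the number. They also leave open whether a longer chain could stand in for the benzyl group on the shared core.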